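From chloro to methoxy: compound 3 to compound 4

The compounds below may be only part of what the source reports. "The series", "measured", "known", "first", "only" and "open" are said of these compounds alone.

Measured so far in an ADME assay on NHDF cells (Homo sapiens) for cytotoxicity, read by MTT assay, with a stated time of 72 h; on this read-out higher numbers stand for weaker inhibition and lower numbers for stronger inhibition:
- compound 1 `COc1ccccc1/C=C1\CCC/C(=C\c2cccc(OC)c2OC)C1=O` gives 31300 nM
- compound 2 `COc1cccc(/C=C2\CCC/C(=C\c3ccc(Cl)cc3Cl)C2=O)c1OC` gives 49200 nM
- compound 3 `COc1cccc(/C=C2\CCC/C(=C\c3ccc(O)c(Cl)c3)C2=O)c1OC` gives 39500 nM

Compound 3 has no gap beyond the scatter to either other compound (a 1.3-fold higher number from compound 1 to compound 3 (0.10 log units; within the scatter); a 1.2-fold lower number from compound 2 to compound 3 (0.10 log units; within the scatter)). The remaining measured step (a 1.6-fold higher number from compound 1 to compound 2 (0.20 log units; within the scatter)) also stays within the scatter. Compound 4 `COc1cc(/C=C2\CCC/C(=C\c3cccc(OC)c3OC)C2=O)ccc1O` differs from compound 3 by methoxy in place of chloro on an aromatic carbon, turning 3-chloro-4-hydroxyphenyl into 4-hydroxy-3-methoxyphenyl. For the measured compounds named here, no measured step makes this exact exchange. Each one swaps a substituted phenyl, however, and none leaves the scatter, so no shift beyond the scatter is expected in this assay here. The expected step is small (a 1.0-fold lower number from compound 3 to compound 4 (0.02 log units; within the scatter)). For compound 4 the estimated value is 38000 nM (expected range 20000 nM to 70000 nM).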

Compound 4, half-maximal inhibitory concentration: 14300 nM
Estimate against measurement, compound 4: 2.7-fold (0.42 log units) above; measured number outside the range, below it.
By their numbers in this assay, from the lowest: compound 4; then compounds 1, 3 and 2 (each within the scatter of the next).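

In this assay, for the compounds shown here, methoxy in place of chloro on an aromatic carbon ortho to a hydroxy group gives a step beyond the scatter, a 2.8-fold lower number from compound 3 to compound 4 (0.44 log units; beyond the scatter), which no earlier step had done. The 4-hydroxy-3-methoxyphenyl group also stands apart from the other substituted phenyls, with a 3.4-fold lower number from compound 2 to compound 4 (0.54 log units; beyond the scatter) and a 2.2-fold lower number from compound 1 to compound 4 (0.34 log units; beyond the scatter), so exchanges at this position can move the number. Nothing available accounts for this shift.

Going by these compounds, whether an ethoxy group or an amine on that carbon would lower the number further remains open. So does the share of the neighbouring hydroxy group in this step.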